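This account rests on a few compounds, and the source may have more. Where it says the series, first, only, none or still open, it means among the compounds named here.

Measured so far in a functional assay on HMEC-1 cells (Homo sapiens) for antiproliferative activity, read by cell counting, with a stated time of 4 days; on this read-out lower numbers stand for stronger inhibition and higher numbers for weaker inhibition

compound 1 `CC(Nc1ccccc1Oc1cccc(F)c1)=C1C(=O)CC(c2ccccc2)CC1=O` gives 360 nM
compound 2 `CC(Nc1ccccc1Oc1ccccc1)=C1C(=O)CC(c2ccccc2)CC1=O` gives 160 nM

Of these two numbers, compound 2 at 160 nM is the lower one. The next analogue, compound 3 `CC(Nc1ccccc1Oc1ccc(C(C)O)cc1)=C1C(=O)CC(c2ccccc2)CC1=O`, carries 1-hydroxyethyl in place of hydrogen on an aromatic carbon on the phenoxy ring, with the new group para to a large group. Among the compounds with values here, only one measured step bears on this: a 2.3-fold lower number from compound 1 to compound 2 (0.35 log units; beyond the scatter) for hydrogen in place of fluoro on an aromatic carbon, modest but beyond the scatter. It concerns a single fluoro and no 1-hydroxyethyl, so it is a weak guide. Data on larger groups at this place are lacking. A modest move to a higher number in this assay is expected, and no change beyond the scatter remains possible. The expected change is a 1.8-fold higher number from compound 2 to compound 3 (0.24 log units; within the scatter) in this estimate. The estimate for compound 3 is 280 nM with an expected range from 80 nM to 950 nM overall.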

Compound 3, half-maximal inhibitory concentration: 140 nM
The estimate for compound 3 lay 2.0-fold (0.30 log units) above the measured number; low and high end bracket the measured number.
By their numbers in this assay, from the lowest: compounds 3 and 2 (each within the scatter of the next); then compound 1.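

In this assay the phenoxy ring carries 1-hydroxyethyl on an aromatic carbon, para to a large group, with a 1.1-fold lower number from compound 2 to compound 3 (0.06 log units; within the scatter), so a group of this size at this place gives no step beyond the scatter. The earlier pair covered only a single fluoro, whereas the swap of 3-fluorophenyl for 4-(1-hydroxyethyl)phenyl gives a 2.6-fold lower number from compound 1 to compound 3 (0.41 log units; beyond the scatter), a modest step that leaves compound 3 with compound 2 on the low side of compound 1. Nothing available explains why the number holds with this larger group.

Whether the hydroxyl matters stays open, since ethyl at the same place is not among the compounds shown. As far as these compounds go, whether an amine, a carboxylic acid or a longer chain there would also stay within the scatter of compound 2 is equally open.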